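This account rests on a few compounds, and the source may have more. Where it says the series, first, only, none or still open, it means among the compounds named here.

Measured so far: compound 1 `O=C(Nc1cccnc1)c1ccccc1OCc1cccc(Cl)c1` with 1400 nM in an assay on lysate for inhibition of phosphatidylcholine:ceramide cholinephosphotransferase 2 (Homo sapiens), read by HPLC, with stated times of 30 min and 2 h; a lower number here means a stronger inhibitor, a higher number a weaker inhibitor; compound 2 `O=C(Nc1cccnc1)c1ccccc1OCc1c(Cl)cccc1Cl` with 690 nM; compound 3 `Cc1c(Cl)cccc1COc1ccccc1C(=O)Nc1cccnc1` with 3800 nM.

Compound 1 stands second highest of the three numbers. Its nearest neighbour is compound 2, reached by a 2.0-fold lower number from compound 1 to compound 2 (0.31 log units; beyond the scatter); the furthest is compound 3, reached by a 2.7-fold higher number from compound 1 to compound 3 (0.43 log units; beyond the scatter). Between those two, a 5.5-fold higher number from compound 2 to compound 3 (0.74 log units; beyond the scatter) marks the widest gap in the set.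

Compound 4 `COc1ccc(Cl)cc1COc1ccccc1C(=O)Nc1cccnc1` is not yet measured. It differs from compound 1 by methoxy in place of hydrogen on an aromatic carbon, that is, a methoxy entering in place of hydrogen on the ring bound through the saturated chain carbon to the ether oxygen, ortho to a large group and para to the chloro group.

For the measured compounds named here, no measured step adds a methoxy anywhere. The two steps from compound 1 are the closest guides: adding a methyl to that same ring gave the modest loss of a 2.7-fold higher number from compound 1 to compound 3 (0.43 log units; beyond the scatter), while moving to two chloro groups gave the modest gain of a 2.0-fold lower number from compound 1 to compound 2 (0.31 log units; beyond the scatter). Both are beyond the scatter but small, so only a modest shift is expected in this assay, with a slight lean toward a higher number given a 2.7-fold higher number from compound 1 to compound 3 (0.43 log units; beyond the scatter).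

Compound 4 is therefore expected at 2000 nM, plausibly between 800 nM and 5000 nM, corresponding to an expected 1.4-fold higher number from compound 1 to compound 4 (0.15 log units; within the scatter).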

Compound 4, half-maximal inhibitory concentration: 670 nM
Beside the measured number, compound 4's estimate is 3.0-fold (0.47 log units) above it; measured number below the stated range.
By their numbers in this assay, from the lowest: compounds 4 and 2 (each within the scatter of the next); then compound 1; then compound 3.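

In this assay, methoxy in place of hydrogen on an aromatic carbon, ortho to a large group and para to a chloro group, gives a 2.1-fold lower number from compound 1 to compound 4 (0.32 log units; beyond the scatter), so this position accepts an added group with a modest gain. The methyl added to the same ring went the other way, with a 2.7-fold higher number from compound 1 to compound 3 (0.43 log units; beyond the scatter), so adding a group to this ring does not in itself cost activity; compounds 3 and 4 differ in more than one place, however, and cannot be compared directly. For the compounds shown here, with its single chloro group, compound 4 at 670 nM lies within the scatter of the dichloro compound 2 at 690 nM, so a second chloro group is not the only change on this ring that gives a number in this range. Nothing available here explains the direction or size of the methoxy step.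

From the compounds shown here alone, it remains open whether a hydroxy group, an ethoxy group or a fluoro group at this position would give a similar number to the methoxy group. Also open, going by these compounds, is whether the methoxy step holds if the chloro group is removed or replaced by a nitrile.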